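Methylsulfanyl in Place of Chloro on the Shared Core

The source may hold more compounds than are shown below. What is called first, only, known or untested is meant among the compounds shown, and "the series" means these compounds.

In a functional assay on KB cells (Homo sapiens) for inhibition (on this read-out lower numbers stand for stronger inhibition and higher numbers for weaker inhibition), compound 2 `O[C@@H]1[C@@H](CCl)OC(n2c(Cl)nc3cc(Cl)c(Cl)cc32)[C@@H]1O` gives 90000 nM and compound 1 `CCOC[C@H]1OC(n2c(Cl)nc3cc(Cl)c(Cl)cc32)[C@H](O)[C@@H]1O` gives 80000 nM, so the two stand level within the scatter. Compound 3 `CSC[C@H]1OC(n2c(Cl)nc3cc(Cl)c(Cl)cc32)[C@H](O)[C@@H]1O` differs from compound 2 in one place: methylsulfanyl in place of chloro on a saturated chain carbon bound to a saturated ring carbon. For the measured compounds named here, the only measured step at this place is a 1.1-fold higher number from compound 1 to compound 2 (0.05 log units; within the scatter), where chloro replaced ethoxy. A shift beyond the scatter is therefore not expected in this assay, and the expected step is a 1.1-fold lower number from compound 2 to compound 3 (0.02 log units; within the scatter). Compound 3 is estimated at 85000 nM, within an expected range of 40000 nM to 160000 nM.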

Compound 3, half-maximal inhibitory concentration: > 100000 nM
Compound 3: only a limit was reported; the forecaster's own chance of this, stated with the estimate: 15%; middle value at least 1.1-fold (0.07 log units) away from the limit.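

In this assay compound 3 gives only a limit, > 100000 nM. On these data alone, the steps read as an at least 1.1-fold higher number from compound 2 to compound 3 (0.04 log units; that floor lies within the scatter) and an at least 1.2-fold higher number from compound 1 to compound 3 (0.09 log units; that floor lies within the scatter), so methylsulfanyl, like chloro and ethoxy, brings no lower number at this place, and the true size of either step remains unknown. What can be read here rests on a single limit: the limit of > 100000 nM in this assay, at which 1 of the 3 values shown sits.

As far as these compounds go, whether an amine or a carboxylic acid on the saturated chain carbon would give a lower number remains open, as does the effect of a longer chain there.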